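This account rests on a few compounds, and the source may have more. Where it says the series, first, only, none or still open, it means among the compounds named here.

Compound 1 `COc1cc(/C=C/C(=O)/C=C/c2cccc3ccccc23)ccc1OCc1cn(CCOc2cc(=O)oc3ccccc23)nn1`: 85%
Compound 2 `COc1cc(/C=C/C(=O)/C=C/c2cccc3ccccc23)ccc1OCc1cn(CCCCCOc2cc(=O)oc3ccccc23)nn1`: 40%
Compound 3 `COc1cccc(/C=C/C(=O)/C=C/c2ccc(OCc3cn(CCCCOc4cc(=O)oc5ccccc45)nn3)c(OC)c2)c1`: 46%

All three were tested in a functional assay on COLO 205 cells (Homo sapiens) for inhibition, read by sulforhodamine B assay, with a stated time of 48 h, tested at 50 uM; on this read-out lower numbers stand for less inhibition of growth and higher numbers for more inhibition of growth at the one concentration tested. There, compound 2 at 40% lies within the scatter of compound 3 at 46%, and well under compound 1 at 85%. Compound 4 `COc1ccccc1/C=C/C(=O)/C=C/c1ccc(OCc2cn(CCCCCOc3cc(=O)oc4ccccc34)nn2)c(OC)c1` departs from compound 2 by one change: 2-methoxyphenyl in place of naphthalen-1-yl on a double-bonded chain carbon bound to a double-bonded chain carbon. Among the measured compounds shown here, no measured pair differs in one place only, so the data give no direct step for this change. Compound 3, which has no naphthalen-1-yl, gives 46%, though it differs from compound 2 elsewhere too. An expected change within the scatter follows, and the estimated step is a number 5 percentage points higher from compound 2 to compound 4 (within the scatter). For compound 4 the estimated value is 45%, with an expected range from 27% to 65%.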

Compound 4, percent growth inhibition at one concentration: 30%
Compound 4: the middle estimate sits 15 percentage points above what was measured; low and high end bracket the measured number.
By their numbers in this assay, from the lowest: compounds 4, 2 and 3 (each within the scatter of the next, the first and the last beyond it); then compound 1.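

In this assay, among the compounds shown here, this is the first direct reading at this place, on a double-bonded chain carbon bound to a double-bonded chain carbon, and it comes to a number 10 percentage points lower from compound 2 to compound 4 (within the scatter). Exchanging naphthalen-1-yl for 2-methoxyphenyl therefore moves the growth inhibition of this pair by no more than the usual scatter. Nothing available explains this result.

On these data alone, what an unsubstituted phenyl, a pyridyl or a 2-aminophenyl would give at this place remains open. So does whether the same exchange reads alike on the chain of compound 1.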